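The source may hold more compounds than are shown below. What is called first, only, known or untested is meant among the compounds shown, and "the series" means these compounds.

Two compounds share one core and differ only in the ring carried on an amide-type nitrogen. Compound 1 `Cc1cc(C#N)cc(C)c1Oc1ccnc(S(=O)(=O)CC(=O)Nc2ccccc2)n1` carries a plain phenyl there; in an ADME assay on MT4 cells (Homo sapiens) for cytotoxicity, read by MTT assay, with a stated time of 4 days (a higher number here means that more compound is tolerated, a lower number that less compound is tolerated), compound 1 gives 29300 nM. Compound 2 `Cc1cc(C#N)cc(C)c1Oc1ccnc(S(=O)(=O)CC(=O)Nc2ccc(Cl)c(Cl)c2)n1` carries a 3,4-dichlorophenyl instead, and in this assay compound 2 gives 11700 nM. Among the compounds with values here, the step of a 2.5-fold lower number from compound 1 to compound 2 (0.40 log units; beyond the scatter) is beyond the scatter, so compound 2 stands lowest of the two numbers, with compound 1 as its only neighbour. Compound 3 `Cc1cc(C#N)cc(C)c1Oc1ccnc(S(=O)(=O)CC(=O)Nc2ccc([N+](=O)[O-])cc2)n1` is the next variation: 4-nitrophenyl in place of 3,4-dichlorophenyl on an amide-type nitrogen. Within the data shown here, the one measured step that bears on this, a 2.5-fold lower number from compound 1 to compound 2 (0.40 log units; beyond the scatter), shows that swapping the ring on this nitrogen moves the number by a modest amount; nothing measured yet says what a 4-nitrophenyl does in this position. Compound 3 is therefore expected to give a step of a 1.5-fold higher number from compound 2 to compound 3 (0.19 log units; within the scatter) that stays within or only just beyond the scatter, most likely a little upward. The estimate for compound 3 in this assay is 18000 nM, with a range from 7000 nM to 45000 nM.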

Compound 3, half-maximal cytotoxic concentration: 59600 nM
Beside the measured number, compound 3's estimate is 3.3-fold (0.52 log units) below it, and the stated range ends below it.
By their numbers in this assay, from the lowest: compound 2; then compound 1; then compound 3.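

In this assay, the ring on the amide-type nitrogen can now be seen to move the number in either direction from the plain phenyl. Nitro in place of hydrogen on an aromatic carbon gives a 2.0-fold higher number from compound 1 to compound 3 (0.31 log units; beyond the scatter), whereas the 3,4-dichlorophenyl ring gave a 2.5-fold lower number from compound 1 to compound 2 (0.40 log units; beyond the scatter), so the two substituted rings fall on opposite sides of the unsubstituted one. The direct swap of 4-nitrophenyl for 3,4-dichlorophenyl gives a 5.1-fold higher number from compound 2 to compound 3 (0.71 log units; beyond the scatter), spanning the whole range seen so far, and nothing available explains why these rings differ in this way.

Within the data shown here, with only three rings, no trend can be drawn from them, since the two substituted rings differ both in the substituent and in where it sits on the ring. A single chlorine would separate the contribution of each chlorine in the 3,4-dichlorophenyl ring, while an amine or a carboxylic acid at the place held by the nitro group would show whether the higher number of compound 3 is particular to nitro or is shared by other groups there.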